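The source may hold more compounds than are shown below. What is called first, only, known or untested is meant among the compounds shown, and "the series" means these compounds.

Compound 3, `Oc1cccc(-c2cc(-c3cccnc3)cc(-c3ccccc3O)n2)c1`, is the only one of the three measured compounds here to give a number in a functional assay on HeLa cells (Homo sapiens) for cytotoxicity, read by CCK-8 assay; a higher number here means a weaker inhibitor, a lower number a stronger inhibitor: compound 3 gives 7530 nM. Compound 1, `Oc1ccc(-c2cc(-c3cccs3)cc(-c3ccccc3O)n2)cc1`, gives only a limit in this assay, > 50000 nM. Compound 2, `Oc1ccc(-c2cc(-c3ccoc3)cc(-c3ccccc3O)n2)cc1`, likewise reaches only the limit of this assay, > 50000 nM. Going by the values given here, the one measured step, a step that the two limits leave unreadable from compound 1 to compound 2, therefore cannot be sized; the limit of > 50000 nM in this assay, at which 2 of the 3 values shown sit, shows where those two values stand. Compound 4, `Oc1ccc(-c2cc(-c3cccnc3)cc(-c3ccccc3O)n2)cc1`, is the compound not yet measured. It differs from compound 3 in one place: 4-hydroxyphenyl in place of 3-hydroxyphenyl on an aromatic carbon. Among the compounds with values here, no measured step changes this same group, so no direct guide to its size exists. What can be said is that compounds 1 and 2 each carry the 4-hydroxyphenyl group that enters in compound 4, and both reach only the limit in this assay, whereas compound 3, carrying the 3-hydroxyphenyl group, gives a number. On that basis compound 4 is expected to be a weaker inhibitor than compound 3, with a 4.0-fold higher number from compound 3 to compound 4 (0.60 log units; beyond the scatter) as the expected step. The estimate for compound 4 in this assay is 30000 nM, with a range from 8000 nM to 100000 nM, and a real chance that only a limit is reported.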

Compound 4, half-maximal inhibitory concentration: > 50000 nM
Compound 4 gave a limit, no number (the forecaster's own chance of this, stated with the estimate: 50%); at least 1.6-fold (0.22 log units) between middle value and limit.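

In this assay, putting 4-hydroxyphenyl in place of 3-hydroxyphenyl on the aromatic carbon next to the ring nitrogen gives an at least 6.6-fold higher number from compound 3 to compound 4 (0.82 log units; beyond the scatter). Going by these compounds alone, this is the first readable step in the set, and it comes from a change that keeps the same atoms and only moves the hydroxy group around the phenyl ring. Compound 1 and compound 2 could not show this, since each differs from compound 3 in more than one place, whereas compound 3 and compound 4 differ in this one place alone. Compound 4 gives only a limit, not a number, so the full size of this step stays unknown, and the steps from compound 1 and compound 2 to compound 4 cannot be read, as both ends of each are limits: the limit of > 50000 nM in this assay, at which 3 of the 4 values shown sit.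

As far as these compounds go, it remains open whether the same move of the hydroxy group would matter with thiophen-2-yl or furan-3-yl in place of pyridin-3-yl. Also open, from the compounds shown here alone, is how the number would respond to a methoxy group or an amine in place of the hydroxy group on this phenyl ring.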